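Furan-3-yl gives way to ethynyl

The source may hold more compounds than are shown below. What is called first, only, known or untested is meant among the compounds shown, and "the series" means these compounds.

Going by the values given here, in a functional assay on HL-60 cells (Homo sapiens) for antiproliferative activity, read by XTT assay, with a stated time of 72 h (a lower number here means a stronger inhibitor, a higher number a weaker inhibitor), compound 3 `CN(C)c1ncnc2c1c(-c1ccoc1)cn2[C@@H]1O[C@H](CO)[C@@H](O)[C@H]1O` gives 1160 nM as the highest of three numbers so far. Compound 1 `C#Cc1cn([C@@H]2O[C@H](CO)[C@@H](O)[C@H]2O)c2ncnc(OC)c12` gives 190 nM and compound 2 `C#Cc1cn([C@@H]2O[C@H](CO)[C@@H](O)[C@H]2O)c2ncnc(SC)c12` gives 50 nM with ethynyl on board, though both also differ from compound 3 in a second place. Between those two, methylsulfanyl in place of methoxy gives a 3.8-fold lower number from compound 1 to compound 2 (0.58 log units; beyond the scatter) as a modest change. Compound 4 `C#Cc1cn([C@@H]2O[C@H](CO)[C@@H](O)[C@H]2O)c2ncnc(N(C)C)c12` keeps the rest of compound 3 and takes ethynyl in place of furan-3-yl on an aromatic carbon. Among the compounds with values here, no measured step makes this exact swap. The values of the two ethynyl compounds therefore offer only indirect support for a lower number. The expected change is a 3.9-fold lower number from compound 3 to compound 4 (0.59 log units; beyond the scatter) in this estimate. Compound 4 is estimated at 300 nM with 80 nM to 1100 nM as its expected range.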

Compound 4, half-maximal inhibitory concentration: 290 nM
Estimate against measurement, compound 4: 1.0-fold (0.01 log units) above; low and high end bracket the measured number.
By their numbers in this assay, from the lowest: compound 2; then compounds 1 and 4 (each within the scatter of the next); then compound 3.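

In this assay, the change from furan-3-yl to ethynyl can now be read directly, with dimethylamino held constant (a 4.0-fold lower number from compound 3 to compound 4 (0.60 log units; beyond the scatter)). With ethynyl kept, the other changed group gives different results: dimethylamino in place of methylsulfanyl produces a clear step (a 5.8-fold higher number from compound 2 to compound 4 (0.76 log units; beyond the scatter)), whereas dimethylamino in place of methoxy does not (a 1.5-fold higher number from compound 1 to compound 4 (0.18 log units; within the scatter)). No measured evidence here explains these numbers.

Going by these compounds alone, only two groups have been compared at the furan-3-yl position with dimethylamino in place. As far as these compounds go, how a nitrile or a longer chain such as propynyl would behave there remains open.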